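Methyl removal on the aryl ring across two thiazole-fused cores

A few compounds are considered here, and "the series" means these few. Any claim that something is new, unique, unknown or untested is made for them only; others in the source may bear on it.

Compound 1 `COc1ccc(C(=O)/C=C\Nc2ccc(-c3nc4cc(OC)c(OC)c(OC)c4s3)cc2C)cc1O` gives 15400 nM in a functional assay on MIA PaCa-2 cells (Homo sapiens) for antiproliferative activity, read by sulforhodamine B assay, with a stated time of 48 h; a higher number here means a weaker inhibitor, a lower number a stronger inhibitor. Compound 2 `COc1ccc(C(=O)/C=C\Nc2ccc(-c3nc4cc(OC)c(OC)c(OC)c4s3)cc2)cc1O` gives 32800 nM in this assay. The change between them, hydrogen in place of methyl on an aromatic carbon, made a 2.1-fold higher number from compound 1 to compound 2 (0.33 log units; beyond the scatter).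

Compound 3 `COc1cc(OC)c2sc(-c3ccc(N/C=C\C(=O)c4cc(OC)c(OC)c(OC)c4)c(C)c3)nc2c1` carries a different core; the difference between the core of compound 1 and the core of compound 3 is not broken down here. In this assay compound 3 gives 17000 nM, which sits within the scatter of compound 1 and, at the far end, of compound 2 as well.

Compound 4 `COc1cc(OC)c2sc(-c3ccc(N/C=C\C(=O)c4cc(OC)c(OC)c(OC)c4)cc3)nc2c1` is the unmeasured partner of compound 3; how it differs from compound 3 is described by hydrogen in place of methyl on an aromatic carbon, the same change as that from compound 1 to compound 2, at the same kind of place. Within the data shown here, the expectation rests on that earlier step: a number higher than that of compound 3 by about the same modest margin, since the only precedent is a 2.1-fold higher number from compound 1 to compound 2 (0.33 log units; beyond the scatter), with a single pair as basis. For compound 4 the estimated step is a 2.0-fold higher number from compound 3 to compound 4 (0.30 log units; within the scatter). Compound 4 is thus expected to give about 34000 nM, with the likely range spanning 17000 nM to 70000 nM.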

Compound 4, half-maximal inhibitory concentration: 26800 nM
For compound 4 the middle estimate is 1.3-fold (0.10 log units) above the measured one; low and high end bracket the measured number.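

In this assay, hydrogen in place of methyl on an aromatic carbon gives a 1.6-fold higher number from compound 3 to compound 4 (0.20 log units; within the scatter), so on this core the step alone cannot be told apart from repeat scatter. Set beside the step on the other core, the two do not differ: the same change on two cores in this assay, a 2.1-fold higher number (0.33 log units; beyond the scatter) from compound 1 to compound 2 and a 1.6-fold higher number (0.20 log units; within the scatter) from compound 3 to compound 4, 1.4-fold (0.13 log units) apart, within the scatter of two such steps. Among these compounds, this is consistent with the change carrying over between these two cores with a similar size, but it rests on two pairs in one assay, only one of the two steps lies beyond the scatter, and it shows neither a general rule for the series nor why the numbers behave this way.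

The compounds shown leave open how ethyl, methoxy or chlorine on the same aromatic carbon would compare with methyl and hydrogen. They also leave open whether a more distant replacement, such as an amine or a carboxylic acid, would follow the same course on both cores.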